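The source may report more compounds than this note shows. Statements on the series, on what has been measured and on what is new or still open speak of the compounds shown alone.

Among the compounds with values here, compound 2 `O=C(/C=C/c1cc2ccccc2[nH]c1=O)c1ccc(O)cc1` and compound 1 `COc1ccc(C(=O)/C=C/c2cc3ccccc3[nH]c2=O)cc1` are the two compounds measured so far. In a functional assay on OVCAR-8 cells (Homo sapiens) for cytotoxicity, read by sulforhodamine B assay, with a stated time of 24 h (a higher number here means a weaker inhibitor of growth, a lower number a stronger inhibitor of growth), compound 2 gives 3230 nM, and in this assay compound 1 gives 3570 nM. The step of a 1.1-fold lower number from compound 1 to compound 2 (0.04 log units; within the scatter), hydrogen in place of methyl on an oxygen on an aromatic ring, lies within the scatter, so the two compounds cannot be told apart on these numbers. Compound 3 `O=C(/C=C/c1cc2ccccc2[nH]c1=O)c1ccc(Cl)cc1` differs from compound 2 by chloro in place of hydroxy on an aromatic carbon, that is, 4-hydroxyphenyl to 4-chlorophenyl. Within the data shown here, the only measured step alters the same group on the same ring and was within the scatter; an exchange of hydroxy for chloro is not covered by any measured pair. Compound 3 is therefore expected to give a number close to that of compound 2, with the estimated step of a 1.1-fold lower number from compound 2 to compound 3 (0.03 log units; within the scatter) not beyond the scatter. The estimate for compound 3 in this assay is 3000 nM, with a range from 1200 nM to 8000 nM.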

Compound 3, concentration for 50% growth inhibition: 4930 nM
The estimate for compound 3 lay 1.6-fold (0.22 log units) below the measured number, and the stated range covers the measured number.
By their numbers in this assay, from the lowest: compounds 2, 1 and 3 (each within the scatter of the next).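

In this assay, chloro in place of hydroxy on this aromatic carbon, para to a large group, gives a 1.5-fold higher number from compound 2 to compound 3 (0.18 log units; within the scatter) and chloro in place of methoxy gives a 1.4-fold higher number from compound 1 to compound 3 (0.14 log units; within the scatter). The position therefore now has a second kind of exchange behind it: hydroxy, with 1 hydrogen-bond donor and 1 hydrogen-bond acceptor, gives way to chloro, with 0 hydrogen-bond donors and 0 hydrogen-bond acceptors, and the numbers for compound 1, compound 2 and compound 3 still cannot be told apart. Nothing shown explains these numbers.

Whether any group at this position can move the number beyond the scatter remains open, since all three groups shown lie within it. From the compounds shown here alone, an amine, a carboxylic acid or a longer alkyl chain here would test this, and the shared core remains unexplored.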